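Shortening the Side Chain of Compound 2

A few compounds are considered here, and "the series" means these few. Any claim that something is new, unique, unknown or untested is made for them only; others in the source may bear on it.

So far, only two compounds have been measured. In a functional assay on SNU1 cells (Homo sapiens) for cytotoxicity (a higher number here means a weaker inhibitor, a lower number a stronger inhibitor), compound 1 (`C=C1CC[C@H]2C(C)(C)CCC[C@]2(C)[C@H]1CC(O)c1ccoc1`) gives 3.9 ug/mL. Compound 2 (`CC(=O)O[C@]1(C)CC[C@H]2C(C)(C)CCC[C@]2(C)[C@H]1C/C=C1/CCOC1=O`) gives 12.3 ug/mL, the higher of the two numbers, which makes it the weaker inhibitor by a gap beyond the usual scatter. The next compound to be tested is compound 3 (`CC(=O)O[C@]1(C)CC[C@H]2C(C)(C)CCC[C@]2(C)[C@H]1CC=O`), which keeps the core of compound 2 but carries a much smaller side group: a group of 2 heavy atoms (1 carbon, 1 oxygen; no ring) in place of a group of 7 heavy atoms (5 carbon, 2 oxygen; one five-membered non-aromatic ring with 1 hetero atom), on a saturated chain carbon bound to a saturated ring carbon. For the measured compounds named here, no measured pair yet shows what such a swap does in this assay, so the data point in neither direction, and no change beyond the scatter is expected. The estimated step is a 1.1-fold higher number from compound 2 to compound 3 (0.06 log units; within the scatter). The uncertainty remains wide. Compound 3 is expected at 14 ug/mL, with an estimated range from 5 ug/mL to 40 ug/mL.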

Compound 3, half-maximal inhibitory concentration: 4.8 ug/mL
Beside the measured number, compound 3's estimate is 2.9-fold (0.46 log units) above it; measured number outside the range, below it.
By their numbers in this assay, from the lowest: compounds 1 and 3 (each within the scatter of the next); then compound 2.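

In this assay, swapping the group of 7 heavy atoms with its five-membered non-aromatic ring for a formyl, on a saturated chain carbon bound to a saturated ring carbon, gives a 2.6-fold lower number from compound 2 to compound 3 (0.41 log units; beyond the scatter). For the compounds shown here, this is the first measured step at this position, and it shows that the larger ring-bearing group is not needed for cytotoxicity here: the much smaller formyl gives the stronger inhibitor. No measurement in hand accounts for this step. Because only one replacement at this place is shown, it remains open whether the stronger inhibition goes with the smaller size of the group or with the formyl itself. A carboxylic acid, an alcohol or a longer chain ending in a formyl at the same place would help to tell these two readings apart.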